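A few compounds are considered here, and "the series" means these few. Any claim that something is new, unique, unknown or untested is made for them only; others in the source may bear on it.

Compound 1 `CC1(C)Cc2c(ccc(C(=O)/C=C/c3ccc(Cl)cc3Cl)c2OCc2ccccc2)O1` gives in a functional assay on B16 cells (Mus musculus) for antiproliferative activity, read by MTT assay, with a stated time of 48 h (a lower number here means a stronger inhibitor, a higher number a weaker inhibitor), only the limit of the assay, > 100000 nM.
Compound 2 `CC1(C)Cc2c(ccc(C(=O)/C=C/c3ccccc3)c2OCc2ccccc2)O1` gives in this assay likewise only a limit, > 100000 nM.
Compound 3 `Cc1ccc(-c2nn(-c3ccccc3)cc2/C=C/C(=O)c2ccc(OCc3ccccc3)c3c2OC(C)(C)C3)cc1` gives in this assay again only a limit, > 100000 nM.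

Compound 2 therefore stands nowhere on a numerical scale: its result is a limit, and the two further values shown for the shared core are limits as well. The step to the unmeasured compound 4 `CC1(C)Cc2c(ccc(C(=O)/C=C/c3ccc(F)cc3)c2OCc2ccccc2)O1` is fluoro in place of hydrogen on an aromatic carbon. Within the data shown here, the only measured step on the same part of the molecule, a step that the two limits leave unreadable from compound 1 to compound 2, cannot be read, since both of its ends are limits; the wider picture is the limit of > 100000 nM in this assay, at which 3 of the 3 values shown sit, which gives no foothold for a direction either. With no readable step to anchor the change from hydrogen to fluoro on the aromatic ring, the expectation for compound 4 is that it will most probably remain at the limit in this assay, so that a number no higher from compound 2 to compound 4 (the limit leaves the size open) is expected to stay within the scatter. Compound 4 is accordingly estimated at 100000 nM, within a range of 30000 nM to 300000 nM.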

Compound 4, half-maximal inhibitory concentration: > 100000 nM
Compound 4 ended at the assay's limit (the forecaster's own chance of this, stated with the estimate: 80%); the middle value lies on the limit itself.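

Compound 4, like compound 1 and compound 2, gives only a limit in this assay, so the steps among these three compounds cannot be read. The compounds shown leave open whether any change on the aromatic ring alters antiproliferative activity, as every result remains a limit: the limit of > 100000 nM in this assay, at which 4 of the 4 values shown sit.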